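Trifluoromethyl Added to the Fluorophenyl Analogue

This account rests on a few compounds, and the source may have more. Where it says the series, first, only, none or still open, it means among the compounds named here.

Three compounds share one core and differ only in the aromatic ring at the chain end. Compound 1 `CC1=C(/C=C/C(=O)/C=C/c2cccc(C(F)(F)F)c2)C(C)(C)CCC1O` carries a trifluoromethyl group, and in a functional assay on PC-3 cells (Homo sapiens) for cytotoxicity, read by MTT assay, with a stated time of 72 h (a higher number here means a weaker inhibitor, a lower number a stronger inhibitor), compound 1 gives 3500 nM. Compound 2 `CC1=C(/C=C/C(=O)/C=C/c2cccc(F)c2)C(C)(C)CCC1O` carries a fluoro in its place; in this assay compound 2 gives 16000 nM, and that exchange gave a 4.6-fold higher number from compound 1 to compound 2 (0.66 log units; beyond the scatter). Compound 3 `CC1=C(/C=C/C(=O)/C=C/c2ccc(F)cc2)C(C)(C)CCC1O` carries 4-fluorophenyl in place of 3-fluorophenyl, and in this assay compound 3 gives 6200 nM, which is a 2.6-fold lower number from compound 2 to compound 3 (0.41 log units; beyond the scatter). Among the three numbers compound 3 stands second highest: its value and that of compound 1 lie within the usual scatter, while compound 2 sits higher.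

Compound 4 `CC1=C(/C=C/C(=O)/C=C/c2ccc(F)c(C(F)(F)F)c2)C(C)(C)CCC1O` is not yet measured. Its change from compound 3 is trifluoromethyl in place of hydrogen on an aromatic carbon, on an aromatic carbon of a six-membered aromatic ring of carbon only, ortho to a fluoro group and meta to a large group. Going by the values given here, the one measured step that bears on this is a 4.6-fold higher number from compound 1 to compound 2 (0.66 log units; beyond the scatter), a modest effect; read the other way, adding trifluoromethyl went with a lower number. Because of a 4.6-fold higher number from compound 1 to compound 2 (0.66 log units; beyond the scatter) a lower number is expected for compound 4, a shift of about a 2.5-fold lower number from compound 3 to compound 4 (0.39 log units; beyond the scatter). Compound 4 keeps its fluoro as well, so the shift may be smaller. The estimate for compound 4 is 2500 nM, within 1000 nM to 6500 nM.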

Compound 4, half-maximal inhibitory concentration: 7300 nM
Beside the measured number, compound 4's estimate is 2.9-fold (0.47 log units) below it; measured number outside the range, above it.
By their numbers in this assay, from the lowest: compounds 1, 3 and 4 (each within the scatter of the next, the first and the last beyond it); then compound 2.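

In this assay, adding trifluoromethyl to this ring carbon, ortho to a fluoro group and meta to a large group, gave a 1.2-fold higher number from compound 3 to compound 4 (0.07 log units; within the scatter), so the lower number that went with trifluoromethyl in the step between compound 1 and compound 2 does not carry over to a ring that keeps its fluoro. Seen from the other side, adding a fluoro gave a 2.1-fold higher number from compound 1 to compound 4 (0.32 log units; beyond the scatter), a modest step, which shows that a fluoro on this ring can matter when trifluoromethyl is already present. Nothing available here explains either step.

The compounds shown leave open whether a different group at this ring carbon, such as an amine or a methoxy group, would move the number away from that of compound 3. They also leave open whether trifluoromethyl would behave the same way alongside a chloro group in place of the fluoro.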